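A few compounds are considered here, and "the series" means these few. Any claim that something is new, unique, unknown or untested is made for them only; others in the source may bear on it.

Working notes on the series.

Of the compounds shown here, three sharing a common core have been measured in an assay on COS-7 cells for agonist activity at Free fatty acid receptor 1 (Homo sapiens), read by scintillation counting and inositol phosphate accumulation, with a stated time of 90 min; on this read-out higher numbers stand for an effect only at larger amounts of compound and lower numbers for an effect already at smaller amounts. Compound 1 `Cc1cc(=O)oc2cc(OCc3nc(N)nc(Nc4cccc(Cl)c4)n3)ccc12` gives 1110 nM. Compound 2 `CCc1ccc(Nc2nc(N)nc(COc3ccc4c(C)cc(=O)oc4c3)n2)cc1Cl` gives 160 nM. Compound 3 `Cc1ccc(Nc2nc(N)nc(COc3ccc4ccc(=O)oc4c3)n2)cc1` gives 1280 nM. Compound 4 `CCc1cc(=O)oc2cc(OCc3nc(N)nc(Nc4ccc(C)cc4)n3)ccc12` has not yet been measured in this assay.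

Compound 1 and compound 2 differ by ethyl in place of hydrogen on an aromatic carbon, and this change produced a 6.9-fold lower number from compound 1 to compound 2 (0.84 log units; beyond the scatter). Compound 3 and compound 1 differ in more than one place; the difference between the two cores is not broken down here. The two values of compound 3 and compound 1 lie within the usual scatter, so no order between them is claimed.

Compound 4 differs from compound 3 by ethyl in place of hydrogen on an aromatic carbon. This is the same kind of change as that from compound 1 to compound 2, but not the same: in the earlier pair the ethyl enters on a six-membered aromatic ring of carbon only, ortho to a chloro group and para to a large group, whereas here it enters on a six-membered aromatic ring with one oxygen, part of a fused system of two rings, ortho to a fused ring and opposite the ring oxygen. Among the measured compounds shown here, since the surroundings of the place differ and only one measured instance of the change exists, the step from compound 3 to compound 4 is expected to be smaller, estimated at a 2.1-fold lower number from compound 3 to compound 4 (0.33 log units; beyond the scatter). Compound 4 is accordingly expected to give about 600 nM, between 200 nM and 2000 nM.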

Compound 4, half-maximal effective concentration: 2640 nM
The estimate for compound 4 lay 4.4-fold (0.64 log units) below the measured number, outside the stated range (above it).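

In this assay, ethyl in place of hydrogen on an aromatic carbon does not keep its direction from one core to the other: here it gives a 2.1-fold higher number from compound 3 to compound 4 (0.31 log units; beyond the scatter), whereas the earlier step ran the opposite way, and the two steps differ clearly: the same change on two cores in this assay, a 6.9-fold lower number (0.84 log units; beyond the scatter) from compound 1 to compound 2 and a 2.1-fold higher number (0.31 log units; beyond the scatter) from compound 3 to compound 4, 14-fold (1.16 log units) apart, beyond the scatter of two such steps

This shows that, within this series, the earlier step cannot be carried over as a fixed increment, or even as a sign, to a different core or a different place of substitution. It does not show what sets the two steps apart: the ethyl enters a six-membered aromatic ring of carbon only in the earlier pair and a six-membered aromatic ring with one oxygen, opposite the ring oxygen, in the new pair, the remainder of the two cores also differs, and each case rests on one pair, so the place of the ethyl and its surroundings cannot be separated.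

The compounds shown leave open how a longer chain such as propyl, or a carboxylic acid, would read at the place opposite the ring oxygen. They also leave open whether ethyl at that place gives the same step when the carbon-only ring carries a chloro group.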